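Trimming the ether tail of compound 2

The source may hold more compounds than are shown below. What is called first, only, known or untested is meant among the compounds shown, and "the series" means these compounds.

Compound 2, `CCOCCOCCN(CCCCCSc1nc(-c2ccccc2)c(-c2ccccc2)[nH]1)C(=O)NC(C)C`, carries a 2-ethoxyethoxy chain on the saturated carbon two bonds from the amide-type nitrogen. Going by the values given here, in an assay on microsomes from liver with sterol O-acyltransferase 1 (Rattus norvegicus) as the target (on this read-out lower numbers stand for stronger inhibition and higher numbers for weaker inhibition), compound 2 gives 30 nM, the lowest of the three numbers known. Its closest companion is compound 3, `COCCOCCN(CCCCCSc1nc(-c2ccc(OC)cc2)c(-c2ccc(OC)cc2)[nH]1)C(=O)NC(C)C`, which in this assay gives 500 nM; furthest is compound 1, `CCN(CC)CCN(CCCCCSc1nc(-c2ccccc2)c(-c2ccccc2)[nH]1)C(=O)NC(C)C`, which gives 660 nM. The one single-site step among these, a 22-fold lower number from compound 1 to compound 2 (1.34 log units; beyond the scatter), shows how much that chain position can matter.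

Compound 4, `CC(C)NC(=O)N(CCCCCSc1nc(-c2ccccc2)c(-c2ccccc2)[nH]1)CCOCCO`, is compound 2 with the change (hydrogen in place of ethyl on an oxygen on a saturated carbon), so the 2-ethoxyethyl group becomes 2-hydroxyethyl. Among the compounds with values here, no measured step trims an ethyl from this oxygen; the step from compound 1 to compound 2 swaps the whole substituent rather than its end, and compound 3 differs from compound 2 in two places at once, so its value can only be noted, not read as a step. The change is small in atoms but sits in a region already shown to be sensitive. A modest loss is expected: compound 4 is estimated at 100 nM, in the range 30 nM to 400 nM, and the expected step is a 3.3-fold higher number from compound 2 to compound 4 (0.52 log units; beyond the scatter).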

Compound 4, half-maximal inhibitory concentration: 90 nM
Estimate against measurement, compound 4: 1.1-fold (0.05 log units) above; the range from low to high includes it.
By their numbers in this assay, from the lowest: compound 2; then compound 4; then compounds 3 and 1 (each within the scatter of the next).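

Removing the ethyl from the end of the chain has a measurable but limited cost in this assay (a 3.0-fold higher number from compound 2 to compound 4 (0.48 log units; beyond the scatter)), so this outer part of the 2-ethoxyethyl group does affect the read-out at a site where only a whole-substituent swap had been seen before. The advantage over the diethylamino compound survives the trimming, since the hydroxy-ended chain still gives a 7.3-fold lower number from compound 1 to compound 4 (0.87 log units; beyond the scatter), which is beyond the scatter and shows that the terminal ethyl is not required for this chain to outperform the diethylamino chain. No evidence available here explains why either change shifts the number.

Steps to compound 3 cannot be read, as it differs from the others in more than one place, so the effect of trimming the chain end on its substituted core remains unknown. The compounds shown also leave open how this position would respond to a carboxylic acid or a primary amine at the chain end, or to a longer chain with a further ethoxy unit.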